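Swapping the ester for methyl on the shared core

The source may hold more compounds than are shown below. What is called first, only, known or untested is meant among the compounds shown, and "the series" means these compounds.

Compound 1 `CC(=O)Oc1ccc2oc(/C=C/[S+](C)[O-])cc(=O)c2c1`: > 10000 nM
Compound 2 `CC(C)COc1ccc2oc(/C=C/[S+](C)[O-])cc(=O)c2c1`: 5000 nM
Compound 3 `CC(C)CC(=O)Oc1ccc2oc(/C=C/[S+](C)[O-])cc(=O)c2c1`: 6100 nM

These three compounds were tested in a functional assay on DLD-1 cells (Homo sapiens) for cytotoxicity, with a stated time of 48 h; a lower number here means a stronger inhibitor, a higher number a weaker inhibitor. For compound 1 the entry > 10000 nM is a limit of the assay and not a number. Going by the values given here, compound 3 gives 6100 nM and cannot be told apart from the only other compound with a true number, as the data show a 1.2-fold higher number from compound 2 to compound 3 (0.09 log units; within the scatter).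

Compound 4 `Cc1ccc2oc(/C=C/[S+](C)[O-])cc(=O)c2c1` has yet to be measured. It brings (methyl in place of (isobutylcarbonyl)oxy on an aromatic carbon), that is, methyl in place of (isobutylcarbonyl)oxy on an aromatic carbon. Among the compounds with values here, no measured step makes this change, so the evidence is indirect. The nearest guide is the swap of isobutyl for isobutylcarbonyl on the oxygen, which stays within the scatter. The two steps that start at the limit give only floors: an at least 2.0-fold lower number from compound 1 to compound 2 (0.30 log units; that floor lies within the scatter) and an at least 1.6-fold lower number from compound 1 to compound 3 (0.21 log units; that floor lies within the scatter). With so small a measured step, no change beyond the scatter is expected for compound 4 in this assay, and no direction can be argued with confidence. The estimate amounts to a 1.1-fold higher number from compound 3 to compound 4 (0.06 log units; within the scatter). Compound 4 is expected at 7000 nM, with an estimated range of 3000 nM to 15000 nM.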

Compound 4, half-maximal inhibitory concentration: 7000 nM
For compound 4 middle estimate and measured number coincide at the digits printed; the range from low to high includes it.
By their numbers in this assay, from the lowest: compounds 2, 3 and 4 (each within the scatter of the next). At a limit, above all of these: compound 1.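

On this aromatic carbon, methyl takes the place of groups attached through oxygen, so compound 4 is the first compound shown with no oxygen at this position. In this assay, this change gives a 1.1-fold higher number from compound 3 to compound 4 (0.06 log units; within the scatter) and a 1.4-fold higher number from compound 2 to compound 4 (0.15 log units; within the scatter), which shows that neither the (isobutylcarbonyl)oxy nor the isobutoxy group is needed to keep the number in this range. The change from acetoxy to methyl gives an at least 1.4-fold lower number from compound 1 to compound 4 (0.15 log units; that floor lies within the scatter), which is only a floor, because the entry for the first of these compounds is a limit and not a number: the limit of > 10000 nM in this assay, at which 1 of the 4 values shown sits.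

From the compounds shown here alone, it remains open whether a hydroxyl, an amine, a carboxylic acid or a much longer chain such as an octyl ether on this aromatic carbon would give a number beyond the scatter of these values. Going by these compounds, the true gap between the acetoxy compound and the other three also stays unknown, so it cannot be said whether that group differs from the rest or whether the position tolerates all four groups alike.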